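The source may hold more compounds than are shown below. What is called first, only, known or untested is meant among the compounds shown, and "the series" means these compounds.

Measured compounds and their numbers:

compound 1 `COc1ccc(N)c(C2=NN(C(C)=O)CC2)c1`: 20.4%
compound 2 `CCCC(=O)N1CCC(c2cc(OC)ccc2N)=N1`: 13.1%

In an assay on isolated protein for inhibition of Nitric oxide synthase, inducible (Homo sapiens), with a stated time of 30 min, tested at 1 mM (on this read-out lower numbers stand for less inhibition and higher numbers for more inhibition at the one concentration tested (going by the name of the read-out)), compound 1 gives 20.4% and compound 2 gives 13.1%. Within the data shown here, the only measured step, a number 7.3 percentage points lower from compound 1 to compound 2 (within the scatter), is within the scatter, and it changed the same acyl group that is changed again here: ethyl in place of hydrogen on a saturated chain carbon bound to a carbonyl carbon. Compound 2 is the lower of the two numbers, but its gap to compound 1 is within the scatter, so the two cannot be told apart on what has been measured.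

Compound 3 `COc1ccc(N)c(C2=NN(C(=O)C3CC3)CC2)c1` is the next member. It differs from compound 2 by cyclopropyl in place of propyl on a carbonyl carbon. Among the measured compounds shown here, the one step that bears on this is the one from compound 1 to compound 2, which worked on the same carbonyl-bound group and produced no movement beyond the scatter. On that basis no step beyond the scatter is expected in this assay; the expected step is a number 0.9 percentage points higher from compound 2 to compound 3 (within the scatter). Compound 3 is therefore estimated at 14%, within a range of 4% to 26%.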

Compound 3, a percentage reported as inhibition, at one concentration (the size of the read-out at that concentration, not a potency): 19.9%
The estimate for compound 3 lay 5.9 percentage points below the measured number; the measured number falls inside the stated range.
By their numbers in this assay, from the lowest: compounds 2, 3 and 1 (each within the scatter of the next).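

At the carbonyl carbon, a three-membered ring of carbon only now stands in for an open chain, and in this assay cyclopropyl in place of propyl gives a number 6.8 percentage points higher from compound 2 to compound 3 (within the scatter) while cyclopropyl in place of methyl gives a number 0.5 percentage points lower from compound 1 to compound 3 (within the scatter) on the same shared core. With the ring added, methyl, propyl and cyclopropyl on this carbonyl carbon still cannot be told apart, so neither the longer chain nor the ring has moved the number beyond the scatter in these three compounds. No measurement is available that would explain this result.

On these data alone, it remains open whether any group on this carbonyl carbon separates from these three in this assay, for example a much longer chain, a phenyl ring, an amine or a carboxylic acid. As far as these compounds go, the methoxy and amino groups of the shared core are the same in all three compounds, so what a change at either of them would do to the number also remains open.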